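Methyl added to the pendant phenyl of compound 2

A few compounds are considered here, and "the series" means these few. Any claim that something is new, unique, unknown or untested is made for them only; others in the source may bear on it.

Compound 1 `COc1ccccc1N1CCN(CCCn2c(=O)[nH]c3cc[nH]c3c2=O)CC1` and compound 2 `COc1ccccc1N1CCN(CCCn2c(=O)[nH]c3cc(-c4ccccc4)[nH]c3c2=O)CC1` are the two members with numbers. In an assay for binding affinity to Adrenergic receptor alpha-1 (Rattus norvegicus) (a lower number here means a stronger inhibitor, a higher number a weaker inhibitor), compound 1 gives 28 nM, and compound 2 gives 1.23 nM. For the measured compounds named here, compound 2 thus holds the lowest of the two numbers, with compound 1 as its only neighbour. Going by the values given here, the one measured step, a 23-fold lower number from compound 1 to compound 2 (1.36 log units; beyond the scatter), came with phenyl in place of hydrogen on an aromatic carbon of the shared core. Compound 3 `COc1ccccc1N1CCN(CCCn2c(=O)[nH]c3cc(-c4ccc(C)cc4)[nH]c3c2=O)CC1` differs from compound 2 by methyl in place of hydrogen on an aromatic carbon; cut one bond further out, the difference reads phenyl to 4-methylphenyl. Among the compounds with values here, no measured step touches a substituent on that phenyl, so the earlier step bears only indirectly, showing that a phenyl at that carbon lowers the number. A methyl alone is a small addition, and no step beyond the scatter is expected in this assay. For compound 3 the expected value is 1 nM (range 0.4 nM to 3 nM), an expected step of a 1.2-fold lower number from compound 2 to compound 3 (0.09 log units; within the scatter) within the scatter.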

Compound 3, inhibition constant: 47.9 nM
Beside the measured number, compound 3's estimate is 48-fold (1.68 log units) below it; measured number above the stated range.
By their numbers in this assay, from the lowest: compound 2; then compounds 1 and 3 (each within the scatter of the next).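

In this assay, the large gain from the phenyl does not survive one added methyl para to a large group: the change to 4-methylphenyl gives a 39-fold higher number from compound 2 to compound 3 (1.59 log units; beyond the scatter) in this series. Against the unsubstituted core, the comparison gives a 1.7-fold higher number from compound 1 to compound 3 (0.23 log units; within the scatter) and thus leaves compound 3 indistinguishable from compound 1, so the benefit of the phenyl depends strongly on what is attached to its far end. The data shown offer no explanation for the size of this step.

From the compounds shown here alone, it remains open whether the loss is specific to methyl or extends to other groups at this place, such as fluorine, methoxy or hydroxyl. Going by these compounds, the effect of a methyl elsewhere on the phenyl also remains open.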